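Working notes: an ethyl step from compound 3

This account rests on a few compounds, and the source may have more. Where it says the series, first, only, none or still open, it means among the compounds named here.

compound 1 `COC1=C(C)C(=O)/C(=C(O)/C=C/c2cc(C)cc(C)c2)C(=O)C1(C)C`: 8.8 ug/mL
compound 2 `COC1=C(C)C(=O)/C(=C(O)/C=C/c2nccs2)C(=O)C1(C)C`: 10.8 ug/mL
compound 3 `COC1=CC(O)=C(C(=O)/C=C/c2ccccc2)C(=O)C1(C)C`: 14.2 ug/mL

In a functional assay on PC-3 cells (Homo sapiens) for cytotoxicity (a lower number here means that less compound is needed, a higher number that more compound is needed for the effect), compound 3 gives 14.2 ug/mL, and this value lies within the scatter of those of compound 1 and compound 2, so the three cannot be told apart. Compound 4 `CCC1=C(OC)C(C)(C)C(=O)C(C(=O)/C=C/c2ccccc2)=C1O` carries ethyl in place of hydrogen on a double-bonded ring carbon of compound 3: ethyl in place of hydrogen on a double-bonded ring carbon.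

Going by the values given here, only one measured step links two compounds that differ in one place: a 1.2-fold higher number from compound 1 to compound 2 (0.09 log units; within the scatter). Among the compounds with values here, it lies within the scatter, but it concerns a different place in the molecule, and no measured pair tests this ring carbon. Compound 1 and compound 2 differ from compound 3 in more than one place, yet their values stay within the scatter of it. No shift beyond the scatter is therefore expected in this assay, and no direction can be supported.

The estimated step is a 1.2-fold lower number from compound 3 to compound 4 (0.07 log units; within the scatter).

For compound 4 the expected value is 12 ug/mL, with an estimated range of 6 ug/mL to 24 ug/mL.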

Compound 4, concentration for half-maximal effect: 18.9 ug/mL
Estimate against measurement, compound 4: 1.6-fold (0.20 log units) below; low and high end bracket the measured number.
By their numbers in this assay, from the lowest: compounds 1, 2, 3 and 4 (each within the scatter of the next, the first and the last beyond it).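

In this assay, going by these compounds alone, the first measured step at this ring carbon is a 1.3-fold higher number from compound 3 to compound 4 (0.12 log units; within the scatter), and it lies within the scatter. This double-bonded ring carbon, next to the ring atom that bears a hydroxy group and next to the ring atom that bears a methoxy group, therefore takes ethyl in place of hydrogen with no shift that can be told from the scatter. No supporting measurement bears on this result.

As far as these compounds go, whether a longer chain such as butyl, an amine or a carboxylic acid on this ring carbon would move the number beyond the scatter stays open. From the compounds shown here alone, it is also open whether ethyl in place of hydrogen would give a similar step on the cores of compound 1 and compound 2.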